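Amino group on compound 1: expected clearance

The compounds below may be only part of what the source reports. "The series", "measured", "known", "first", "only" and "open" are said of these compounds alone.

In an ADME assay on microsomes (Mus musculus) for metabolic stability, read by LC-MS, using NADPH, with a stated time of 1 h, tested at 1 uM (on this read-out higher numbers stand for fast clearance and lower numbers for slow clearance), compound 1 (`O=c1ccc(-c2ccc3cn[nH]c3c2)cn1Cc1ccccc1`) gives 157 mL.min-1.g-1 and stands highest of the two measured compounds. Compound 2 (`O=c1ccc(-c2ccc3cn[nH]c3c2)cn1Cc1cccc(Cl)c1`) gives 52 mL.min-1.g-1 and is its nearest neighbour. For the measured compounds named here, the one measured step (a 3.0-fold lower number from compound 1 to compound 2 (0.48 log units; beyond the scatter)) is modest, though beyond the scatter, and concerns chloro in place of hydrogen at another site. Going by the values given here, compound 3 (`Nc1n[nH]c2cc(-c3ccc(=O)n(Cc4ccccc4)c3)ccc12`) differs from compound 1 by amino in place of hydrogen on an aromatic carbon and no measured step covers this change. Judging only by the size of that step (a 3.0-fold lower number from compound 1 to compound 2 (0.48 log units; beyond the scatter)), a modest move in this assay is expected, leaning tentatively lower. The expected step is a 1.4-fold lower number from compound 1 to compound 3 (0.15 log units; within the scatter) in this estimate. For compound 3 the estimate is 110 mL.min-1.g-1 (expected range 45 mL.min-1.g-1 to 260 mL.min-1.g-1).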

Compound 3, intrinsic clearance in microsomes: < 10 mL.min-1.g-1
Compound 3 was reported as a limit; the forecaster's own chance of this, stated with the estimate: 5%; middle value at least 11-fold (1.04 log units) from the limit.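

In this assay this aromatic carbon of the five-membered aromatic ring with 2 nitrogen proves a sensitive site. Amino in place of hydrogen gives an at least 15-fold lower number from compound 1 to compound 3 (1.19 log units; beyond the scatter) and so outruns the only earlier change, chloro in place of hydrogen at another site, which gave a 3.0-fold lower number from compound 1 to compound 2 (0.48 log units; beyond the scatter) as a modest step. The value for compound 3 is a limit and not a number: the limit of < 10 mL.min-1.g-1 in this assay, at which 1 of the 3 values shown sits.

Going by these compounds, whether the step belongs to amino itself or to any group on this carbon stays open, and a methyl or hydroxyl group here would separate the two. Also open, on these data alone, is how amino and chloro would act together on the core of compound 1.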